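The source may hold more compounds than are shown below. What is called first, only, known or untested is meant among the compounds shown, and "the series" means these compounds.

Measured compounds:
compound 1 `COc1cc(-c2cc(/C=C/C(=O)c3ccc(N)cc3)[nH]n2)cc(OC)c1OC` gives 1410 nM
compound 2 `COc1ccc(-c2cc(/C=C/C(=O)c3ccc(OC)c(OC)c3)[nH]n2)cc1` gives 1380 nM

In a functional assay on KM12 cells (Homo sapiens) for inhibition, read by sulforhodamine B assay, with a stated time of 48 h (a higher number here means a weaker inhibitor of growth, a lower number a stronger inhibitor of growth), compound 1 stands at 1410 nM, the highest of the two numbers, yet compound 2 at 1380 nM lies within the scatter of it, so no order between them can be read. Compound 3 `COc1ccc(C(=O)/C=C/c2cc(-c3cc(OC)c(OC)c(OC)c3)n[nH]2)cc1OC` remains to be measured. It differs from compound 1 in one place: 3,4-dimethoxyphenyl in place of 4-aminophenyl on a carbonyl carbon. Among the compounds with values here, no two measured compounds differ in only one place, so there is no measured step to lean on. Within the data shown here, the group entering is the one already carried by compound 2, and compound 2 at 1380 nM sits level with compound 1. A small step in this assay is therefore expected, downward if anything, and likely not beyond the scatter. Compound 3 is expected near 1000 nM, with a range of 400 nM to 3000 nM. The step this estimate implies, a 1.4-fold lower number from compound 1 to compound 3 (0.15 log units; within the scatter), is expected to be modest.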

Compound 3, concentration for 50% growth inhibition: 1070 nM
For compound 3 the middle estimate is 1.1-fold (0.03 log units) below the measured one; the range from low to high includes it.
By their numbers in this assay, from the lowest: compounds 3, 2 and 1 (each within the scatter of the next).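

In this assay, within the data shown here, the exchange of 4-aminophenyl for 3,4-dimethoxyphenyl on a carbonyl carbon gives the first one-place step (a 1.3-fold lower number from compound 1 to compound 3 (0.12 log units; within the scatter)). At this position, then, the group with 7 heavy atoms and 1 hydrogen-bond donor and the group with 10 heavy atoms and 0 hydrogen-bond donors cannot be told apart in this read-out, even though one carries nitrogen and the other oxygen. No measurement on hand offers an explanation for this result.

On these data alone, whether a carboxylic acid or a longer alkyl chain in place of these aromatic groups on the carbonyl carbon would give a step beyond the scatter remains open. A single step also leaves open whether the same exchange would read alike on a different core.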